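This account rests on a few compounds, and the source may have more. Where it says the series, first, only, none or still open, it means among the compounds named here.

Three compounds set the scene. Compound 1 `Oc1ccc(CNc2cc(Br)cc3[nH]ncc23)cc1` is tested in an assay for inhibition of Indoleamine 2,3-dioxygenase 1 (Homo sapiens), read by spectrophotometry, with a stated time of 180 min, tested at 10 uM (a higher number here means a stronger effect of the compound at the concentration tested, a lower number a weaker effect), where compound 1 gives 70%. Compound 3 `Cc1ccc(CNc2cc(Br)cc3[nH]ncc23)cc1` gives 20% in this assay, and compound 2 `O=C(CNc1cc(Br)cc2[nH]ncc12)Nc1ccc(C(=O)O)cc1` gives 12% in this assay. Compound 1 thus stands highest of the three, with compound 3 nearest and compound 2 furthest behind.

Among the compounds with values here, the only single-point step among the measured compounds runs from the hydroxy to the methyl analogue: a number 50 percentage points lower from compound 1 to compound 3 (beyond the scatter). It shows that the hydroxy group on the outer ring of compound 1 carries much of its inhibition.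

Compound 4 `O=C(O)c1cc(CNc2cc(Br)cc3[nH]ncc23)ccc1O` keeps that hydroxy group and differs from compound 1 in one place: carboxy in place of hydrogen on an aromatic carbon. Within the data shown here, no measured step tells what a carboxy group does on this ring, ortho to the hydroxy group. Compound 2 carries a carboxy group on a differently linked ring and gives a low number, but that pair differs in more than one place, so only the two values can be compared. The hydroxy group that mattered in the step to compound 3 is retained, so a collapse is not expected, yet the added group leaves room for change in either direction.

Compound 4 is therefore estimated to give 45%, within a range from 15% to 75%. This estimate means an expected step of a number 25 percentage points lower from compound 1 to compound 4 (beyond the scatter).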

Compound 4, a percentage reported as inhibition, at one concentration (the size of the read-out at that concentration, not a potency): 38%
Beside the measured number, compound 4's estimate is 7 percentage points above it; the range from low to high includes it.
By their numbers in this assay, from the lowest: compounds 2 and 3 (each within the scatter of the next); then compound 4; then compound 1.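

Carboxy in place of hydrogen on an aromatic carbon, ortho to a hydroxy group, gives a number 32 percentage points lower from compound 1 to compound 4 (beyond the scatter) in this assay. Within the data shown here, this is the first reading at this position, and it shows that the position is sensitive: the earlier step changed the hydroxy group itself, whereas here the hydroxy group stays and a large share of the inhibition of compound 1 is still lost, so that group alone does not secure the full effect, although compound 4 keeps a clear reading of 38%. No measurement at hand explains the drop, and the size of the step is all that can be stated about this change.

As far as these compounds go, it stays open whether this loss belongs to the carboxy group itself or would come with any group on this carbon, and a methyl group, a fluorine atom, a methoxy group or the methyl ester of the carboxylic acid at this position would tell these cases apart. From the compounds shown here alone, it also stays open what a carboxy group or an amine would do on the other carbons of this ring, with the hydroxy group kept in place.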